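The source may report more compounds than this note shows. Statements on the series, on what has been measured and on what is new or still open speak of the compounds shown alone.

Compound 3, with the structure `COc1cc(-c2nn(-c3cccc(NC(=O)Nc4cccc(C(F)(F)F)c4)c3)cc2-c2ccncc2)ccc1Cl`, is one of three ureas that share a common core and differ only in the aryl group on the terminal amide-type nitrogen. In a functional assay on SF-268 cells (Homo sapiens) for inhibition, read by sulforhodamine B assay, with a stated time of 48 h (a lower number here means a stronger inhibitor of growth, a higher number a weaker inhibitor of growth), compound 3 gives 1360 nM. Compound 1, `COc1cc(-c2nn(-c3cccc(NC(=O)Nc4cc(C(F)(F)F)cc(C(F)(F)F)c4)c3)cc2-c2ccncc2)ccc1Cl`, gives 978 nM in this assay, and compound 2, `COc1cc(-c2nn(-c3cccc(NC(=O)Nc4ccc(Cl)c(Cl)c4)c3)cc2-c2ccncc2)ccc1Cl`, gives 1510 nM. On these numbers compound 3 stands second highest of the three, nearest to compound 2 and furthest from compound 1, and both gaps are within the scatter: a 1.4-fold higher number from compound 1 to compound 3 (0.14 log units; within the scatter), a 1.1-fold lower number from compound 2 to compound 3 (0.05 log units; within the scatter).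

The step to compound 4, `COc1cc(-c2nn(-c3cccc(NC(=O)c4ccccc4)c3)cc2-c2ccncc2)ccc1Cl`, is of a different kind. Here the change is phenyl in place of (3-(trifluoromethyl)phenyl)amino on a carbonyl carbon. The measured steps only tell how the aryl group on the amide-type nitrogen may be varied, and those variations left this assay essentially unchanged. Nothing measured tells what happens when the (3-(trifluoromethyl)phenyl)amino group leaves altogether and a phenyl sits directly on the carbonyl carbon. Given the indifference of this assay to the aryl variations, but with no guide for the loss of the amide-type nitrogen, a modest weakening is expected: compound 4 is estimated at 3000 nM, within 1000 nM to 9000 nM, which means an expected step of a 2.2-fold higher number from compound 3 to compound 4 (0.34 log units; beyond the scatter).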

Compound 4, concentration for 50% growth inhibition: 859 nM
Compound 4: middle estimate off by 3.5-fold (0.54 log units), on the high side; the whole stated range lies above it.
By their numbers in this assay, from the lowest: compounds 4, 1, 3 and 2 (each within the scatter of the next).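

Within the data shown here, until this result, only the aryl group on the amide-type nitrogen had been varied, and compound 4 extends the picture to the linking nitrogen itself. With phenyl directly on the carbonyl carbon, the amide-type nitrogen, its hydrogen-bond donor and the trifluoromethyl group are all gone, yet this assay records only (a 1.6-fold lower number from compound 3 to compound 4 (0.20 log units; within the scatter)) and, against the dichlorinated urea, (a 1.8-fold lower number from compound 2 to compound 4 (0.24 log units; within the scatter)), both steps within the scatter, so at this position neither that nitrogen nor a substituent on the terminal ring is needed for growth inhibition at this level in these compounds. No measured evidence bears on why this replacement is tolerated.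

The compounds shown leave open whether the terminal aromatic ring is needed at all, since a small methyl group or a longer alkyl chain on the carbonyl carbon would test this directly, as would a cyclic amine such as morpholine or a carboxylic acid placed on the terminal phenyl. They also leave open whether the carbonyl itself matters, and whether a trifluoromethyl group on the phenyl of compound 4 would behave as it does in the ureas.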